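A few compounds are considered here, and "the series" means these few. Any claim that something is new, unique, unknown or untested is made for them only; others in the source may bear on it.

Of the compounds shown here, three have been measured in a functional assay on HeLa cells (Homo sapiens) for inhibition, read by cell counting, with a stated time of 4 days; a lower number here means a stronger inhibitor, a higher number a weaker inhibitor. Compound 1 `C=C(Br)C(=O)Nc1cccc(-c2cn3nc(-c4ccc(F)cc4)sc3n2)c1` gives 870 nM, compound 2 `CCOc1ccc(-c2nn3cc(-c4cccc(N)c4)nc3s2)cc1` gives 94000 nM, and compound 3 `Nc1cccc(-c2cn3nc(-c4ccccc4)sc3n2)c1` gives 26000 nM. Compound 3 thus holds the second highest of the three numbers: its nearest neighbour is compound 2, while compound 1 lies much further away with a far lower number, although compound 1 differs from compound 3 in more than one place.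

For the measured compounds named here, the only single-point step available is the one from compound 2 to compound 3, where an ethoxy group on the same aromatic carbon was removed and the number fell, a 3.6-fold lower number from compound 2 to compound 3 (0.56 log units; beyond the scatter). Compound 4 `Nc1cccc(-c2cn3nc(-c4ccc(F)cc4)sc3n2)c1` differs from compound 3 at that same carbon: fluoro in place of hydrogen on an aromatic carbon, a fluoro in place of hydrogen, sitting para to a large group. Because the step of a 3.6-fold lower number from compound 2 to compound 3 (0.56 log units; beyond the scatter) was modest even when a whole ethoxy was exchanged, the introduction of a single fluorine atom here is expected to move this assay only slightly, if at all, and the step from compound 3 to compound 4 is estimated at a 1.3-fold lower number from compound 3 to compound 4 (0.11 log units; within the scatter). Compound 4 is therefore expected to give about 20000 nM, with a likely range from 7000 nM to 60000 nM.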

Compound 4, half-maximal inhibitory concentration: >= 250000 nM
Compound 4 ended at the assay's limit; the forecaster's own chance of this, stated with the estimate: 5%; middle value at least 12-fold (1.09 log units) from the limit.
By their numbers in this assay, from the lowest: compound 1; then compound 3; then compound 2. At a limit, above all of these: compound 4.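

Compound 4 stands at a limit of this assay, so it has no exact number: the limit of >= 250000 nM in this assay, at which 1 of the 4 values shown sits.

Even so, a single atom at this carbon, para to a large group, makes a clear difference: with fluoro in place of hydrogen there is an at least 9.6-fold higher number from compound 3 to compound 4 (0.98 log units; beyond the scatter), and with fluoro in place of ethoxy there is an at least 2.6-fold higher number from compound 2 to compound 4 (0.42 log units; beyond the scatter), so among these three compounds the number does not follow the size of the group, since the smallest change gives the largest step and hydrogen gives the lowest number. The 4-fluorophenyl group also does not rule out a low number elsewhere in the series, since placing (1-bromoethenyl)carbonyl on the nitrogen in place of hydrogen accounts for an at least 280-fold higher number from compound 1 to compound 4 (2.45 log units; beyond the scatter), the largest step here.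

From the compounds shown here alone, it remains open whether a chloro, methyl or methoxy group at this carbon would keep the number near that of the hydrogen compound or push it towards the limit. Also open, going by these compounds, is whether an acetyl group on the nitrogen, which has no bromine, would bring a similar drop, and whether the (1-bromoethenyl)carbonyl group would give a lower number still on the plain phenyl.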